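Swapping an Acid Tail for a Bulky Hydrocarbon Tail

The compounds below may be only part of what the source reports. "The series", "measured", "known", "first", "only" and "open" are said of these compounds alone.

Three compounds have been measured in a functional assay on MCF7 cells (Homo sapiens) for antiproliferative activity; a higher number here means a weaker inhibitor, a lower number a stronger inhibitor:

Compound 1 `CCNCCCOc1ccc2cc(NC(=O)c3ccc(O)c(CC=C(C)C)c3)c(=O)oc2c1C` gives 980 nM.
Compound 2 `CCCNCCCOc1ccc2cc(NC(=O)c3ccc(O)c(CC=C(C)C)c3)c(=O)oc2c1C` gives 980 nM.
Compound 3 `CC(C)=CCc1cc(C(=O)Nc2cc3ccc(OCCCNCC(=O)O)c(C)c3oc2=O)ccc1O` gives 18100 nM.

Compound 3 stands at the highest number of the three, the weakest inhibitor in this set; its steps to compound 1 and to compound 2 both lie beyond the scatter. Compound 4 `CC(C)=CCc1cc(C(=O)Nc2cc3ccc(OCCCNC(C)(C)c4ccccc4)c(C)c3oc2=O)ccc1O` differs from compound 3 in one place: 1-methyl-1-phenylethyl in place of carboxymethyl on an amine nitrogen. Among the measured compounds shown here, two measured steps bear on this change, an 18-fold higher number from compound 1 to compound 3 (1.27 log units; beyond the scatter) and an 18-fold higher number from compound 2 to compound 3 (1.27 log units; beyond the scatter). Both show that a carboxy group on the chain carbon bound to the amine nitrogen went with a large loss of potency, while no change at the digits printed from compound 1 to compound 2 (within the scatter) shows that the length of a plain hydrocarbon group on that nitrogen made no difference. For the measured compounds named here, compound 4 removes the carboxy group and carries a hydrocarbon group in its place; no measured compound carries an aromatic ring there, so the effect of that ring is unknown. Compound 4 is therefore expected to show a step of a 15-fold lower number from compound 3 to compound 4 (1.18 log units; beyond the scatter), returning roughly to the level of the first two compounds. The estimate for compound 4 is 1200 nM, within a range from 400 nM to 4000 nM.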

Compound 4, half-maximal inhibitory concentration: 1070 nM
Beside the measured number, compound 4's estimate is 1.1-fold (0.05 log units) above it; the measured number falls inside the stated range.
By their numbers in this assay, from the lowest: compounds 1, 2 and 4 (each within the scatter of the next); then compound 3.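

In this assay the change from carboxymethyl to 1-methyl-1-phenylethyl gives a 17-fold lower number from compound 3 to compound 4 (1.23 log units; beyond the scatter) and so shows that this amine nitrogen can carry a six-membered aromatic ring with no visible cost. Against the plain chains the readings are a 1.1-fold higher number from compound 1 to compound 4 (0.04 log units; within the scatter) and a 1.1-fold higher number from compound 2 to compound 4 (0.04 log units; within the scatter) and place 1-methyl-1-phenylethyl with ethyl and propyl, so the earlier match between those two small groups now extends to a group of 9 heavy atoms. No measurement at hand explains this tolerance.

Still open, as far as these compounds go, is whether the aromatic ring or the two methyl groups of 1-methyl-1-phenylethyl contribute anything, which a simple benzyl group on the same nitrogen could separate. Also open, from the compounds shown here alone, is whether the free carboxylic acid itself goes with the weak reading of compound 3, a question a methyl ester of the carboxymethyl group would address.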